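The source may hold more compounds than are shown below. What is called first, only, known or untested is meant among the compounds shown, and "the series" means these compounds.

In a functional assay on NCI-H460 cells (Homo sapiens) for inhibition, read by MTT assay, with a stated time of 48 h (on this read-out higher numbers stand for weaker inhibition and lower numbers for stronger inhibition), three compounds with a shared core have been measured:

Compound 1 `O=C(CC(c1ccccc1)C(C(=O)Nc1ccccn1)C(=O)Nc1ccccn1)c1ccccc1`: "not active" (no number reported)
Compound 2 `O=C(CC(c1ccc([N+](=O)[O-])cc1)C(C(=O)Nc1ccccn1)C(=O)Nc1ccccn1)c1ccccc1`: "not active" (no number reported)
Compound 3 `O=C(CC(c1ccc(Cl)cc1Cl)C(C(=O)Nc1ccccn1)C(=O)Nc1ccccn1)c1ccccc1`: 13100 nM

Compound 3, at 13100 nM, is the only one of the three with a number, so there is no numerical comparison yet. Compound 4 `COc1ccc(C(CC(=O)c2ccccc2)C(C(=O)Nc2ccccn2)C(=O)Nc2ccccn2)cc1` has not been measured. It carries 4-methoxyphenyl in place of 2,4-dichlorophenyl on a saturated chain carbon bound to two saturated chain carbons. For the measured compounds named here, no measured pair shows this change directly. Compound 1 gives "not active" (no number reported) and compound 2 gives "not active" (no number reported), and neither carries chlorine, like compound 4. A modest move towards weaker inhibition in this assay is therefore expected, and possibly no number at all. The estimated change is a 1.9-fold higher number from compound 3 to compound 4 (0.28 log units; within the scatter). For compound 4 the expected value is 25000 nM, within an estimated range of 9000 nM to 70000 nM.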

Compound 4, half-maximal inhibitory concentration: "not active" (no number reported)
No number was reported for compound 4; the estimate stays without a comparison.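

For the compounds shown here, compound 4, like compound 1 and compound 2, has no reported number, so no step from compound 3 to compound 4 can be read. From the compounds shown here alone, how far 4-methoxyphenyl and 2,4-dichlorophenyl differ in numbers stays open. Nothing shown here offers an explanation.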